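Changing the aryl group on the imine carbon of compound 1

A few compounds are considered here, and "the series" means these few. Any claim that something is new, unique, unknown or untested is made for them only; others in the source may bear on it.

Measured so far:
compound 1, `O=C(NNc1ccnc2cc(Cl)ccc12)c1ccccc1/N=C/c1ccc(Br)cc1`, 5.76
compound 2, `O=C(NNc1ccnc2cc(Cl)ccc12)c1ccccc1/N=C/c1cccs1`, 4.78

Compound 1 stands highest of the two numbers in a physicochemical assay for lipophilicity, measured as octanol-water partition (on this read-out lower numbers stand for lower lipophilicity and higher numbers for higher lipophilicity), and compound 2 is nearest, with a number 0.98 log units lower from compound 1 to compound 2 (beyond the scatter). Compound 3, `O=C(NNc1ccnc2cc(Cl)ccc12)c1ccccc1/N=C/c1cc2ccccc2nc1Cl`, has not yet been measured in this assay. It differs from compound 1 as follows: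

2-chloroquinolin-3-yl in place of 4-bromophenyl on a carbon with a double bond to nitrogen

Going by the values given here, the one measured step that bears on this change is the one from compound 1 to compound 2, where a different aromatic ring on the same carbon gave a number 0.98 log units lower from compound 1 to compound 2 (beyond the scatter). Here the entering ring carries a hetero atom too, but it is larger than the leaving one and keeps a halogen. The two effects are expected to pull against each other, so the step to compound 3 is expected to be small or none beyond the scatter, given as a number 0.16 log units lower from compound 1 to compound 3 (within the scatter). Compound 3 is therefore estimated at 5.6, with a range from 5 to 6.2.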

Compound 3, partition coefficient: 6
The estimate for compound 3 lay 0.40 log units below the measured number; low and high end bracket the measured number.
By their numbers in this assay, from the lowest: compound 2; then compounds 1 and 3 (each within the scatter of the next).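

In this assay, the 2-chloroquinolin-3-yl group on the carbon with a double bond to nitrogen gives a number 0.24 log units higher from compound 1 to compound 3 (within the scatter) so that, despite 11 heavy atoms against 7 and a hydrogen-bond acceptor, it cannot be told apart from 4-bromophenyl here. Against thiophen-2-yl, the same group gives a number 1.22 log units higher from compound 2 to compound 3 (beyond the scatter) and so shows that a hetero atom in the ring at this place does not by itself go with a lower number: compound 2 has the lower number, while compound 3 does not. No measured evidence accounts for either step. The compounds shown leave open what the chlorine of 2-chloroquinolin-3-yl contributes on its own. They also leave open how the number would move with an amine or a carboxylic acid on the ring at this place.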